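Swapping the aryl group on a triazole nitrogen

This account rests on a few compounds, and the source may have more. Where it says the series, first, only, none or still open, it means among the compounds named here.

Compound 1 `CCOc1ccccc1-n1nncc1CN1C(=O)C2(C(C#N)=C(N)Oc3c2c2nc4ccccc4nc2c2ccccc32)c2ccccc21`: > 50000 nM
Compound 2 `N#CC1=C(N)Oc2c(N)cc3nc4ccccc4nc3c2C12C(=O)N(Cc1cnnn1-c1ccccc1Br)c1ccccc12`: 30700 nM

In a functional assay on MCF7 cells (Homo sapiens) for antiproliferative activity, read by MTT assay, with a stated time of 48 h (a lower number here means a stronger inhibitor, a higher number a weaker inhibitor), compound 1 reaches only the limit of the measurement, > 50000 nM, so it gives no number. For the measured compounds named here, compound 2, with its amine-bearing core, is the only compound with a real value in this assay, 30700 nM, and that value stands far from strong inhibition. Compound 3 `CCc1cccc(CC)c1-n1nncc1CN1C(=O)C2(C(C#N)=C(N)Oc3c(N)cc4nc5ccccc5nc4c32)c2ccccc21` has not been measured. It keeps the core of compound 2 and changes one thing: 2,6-diethylphenyl in place of 2-bromophenyl on an aromatic nitrogen. Going by the values given here, with a single measured number and no measured step to lean on, there is little to predict from; a shift in either direction that stays within the usual scatter, or no shift at all, is what is expected. Compound 3 is therefore estimated to give 35000 nM in this assay, within 12000 nM to 100000 nM, an expected step from compound 2 to compound 3 of a 1.1-fold higher number from compound 2 to compound 3 (0.06 log units; within the scatter).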

Compound 3, half-maximal inhibitory concentration: > 50000 nM
Compound 3: a limit, no number; the forecaster's own chance of this, stated with the estimate: 40%; middle value at least 1.4-fold (0.15 log units) from the limit.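

Placing 2,6-diethylphenyl on the aromatic nitrogen in place of 2-bromophenyl gives the first readable step at this position in this assay, though only as a floor: an at least 1.6-fold higher number from compound 2 to compound 3 (0.21 log units; that floor lies within the scatter). Going by these compounds, compound 3 stands at a limit, so the true size of the step is unknown and this floor alone does not separate it from compound 2. Compound 3 also shows that keeping the amine-bearing core of compound 2 does not ensure a measurable value once this aryl group changes, and the readings meet a shared ceiling: the limit of > 50000 nM in this assay, at which 2 of the 3 values shown sit.

The compounds shown leave open how far the value at this position can move in either direction. A plain phenyl or a pyridine ring on the same nitrogen, on the core of compound 2, could test whether any aryl group here gives a value well clear of this limit.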